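Extending an amide to a cinnamide on a shared core

The source may report more compounds than this note shows. Statements on the series, on what has been measured and on what is new or still open speak of the compounds shown alone.

Measured so far in an assay on isolated protein for inhibition of RAC-alpha serine/threonine-protein kinase (Homo sapiens), read by fluorescence, with a stated time of 30 min, tested at 10 uM; a higher number here means more inhibition at the concentration tested (going by the name of the read-out), a lower number less inhibition:
compound 1 `O=C(/C=C/c1ccc([N+](=O)[O-])cc1)Nc1cc(Sc2ncn[nH]2)c(O)c2ccccc12`, 40.6%
compound 2 `O=C(Nc1cc(Sc2ncn[nH]2)c(O)c2ccccc12)c1ccc2ccccc2c1`, 41.6%
compound 3 `O=C(Nc1cc(Sc2ncn[nH]2)c(O)c2ccccc12)c1ccc(Cl)cc1`, 50.1%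

Compound 3 gives the highest of the three numbers, yet the step of a number 8.5 percentage points higher from compound 2 to compound 3 (within the scatter) is within the scatter, and the gap to compound 1 is within the scatter too. Compound 4 `O=C(/C=C/c1ccc(Cl)cc1)Nc1cc(Sc2ncn[nH]2)c(O)c2ccccc12` differs from compound 3 in one place: 2-(4-chlorophenyl)ethenyl in place of 4-chlorophenyl on a carbonyl carbon. For the measured compounds named here, no measured step matches this change directly. The nearest hint is compound 1, which also carries an ethenyl link to its ring and in this assay gives 40.6%, a number within the scatter of compound 3. Compound 4 is therefore expected to show a number 5.1 percentage points lower from compound 3 to compound 4 (within the scatter), no step beyond the scatter. The estimate for compound 4 in this assay is 45%, between 28% and 62%.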

Compound 4, a percentage reported as inhibition, at one concentration (the size of the read-out at that concentration, not a potency): 31.8%
Compound 4: the middle estimate sits 13.2 percentage points above what was measured; the measured number falls inside the stated range.
By their numbers in this assay, from the lowest: compounds 4, 1, 2 and 3 (each within the scatter of the next, the first and the last beyond it).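

In this assay, for the compounds shown here, the change on the carbonyl carbon gives the first step beyond the scatter in this set (a number 18.3 percentage points lower from compound 3 to compound 4 (beyond the scatter)): with the 4-chlorophenyl ring kept, 2-(4-chlorophenyl)ethenyl carries less inhibition. The other two steps stay within the scatter, both the one from the naphthalen-2-yl amide (a number 9.8 percentage points lower from compound 2 to compound 4 (within the scatter)) and chloro in place of nitro on an aromatic carbon (a number 8.8 percentage points lower from compound 1 to compound 4 (within the scatter)). Nothing at hand explains the drop. Still open, on these data alone, is how a saturated ethyl link, or an amine or methoxy in place of chloro, would read in this assay.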